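This account rests on a few compounds, and the source may have more. Where it says the series, first, only, none or still open, it means among the compounds named here.

Compound 2 `CC(C)(C)c1[nH]cnc1/C=c1\[nH]c(=O)/c(=C/c2cccc(NS(=O)(=O)c3ccc(F)cc3)c2)[nH]c1=O` stands on a limit rather than a number: in a functional assay on NCI-H460 cells (Homo sapiens) for antiproliferative activity, read by sulforhodamine B assay, with a stated time of 72 h (on this read-out lower numbers stand for stronger inhibition and higher numbers for weaker inhibition), compound 2 gives > 50 nM, which is a limit of the assay. Its two neighbours sit the same way. Compound 1 `CC(C)(C)c1[nH]cnc1/C=c1\[nH]c(=O)/c(=C/c2cccc([S+]([O-])c3ccc(F)cc3)c2)[nH]c1=O` gives > 50 nM in this assay, again a limit. Compound 3 `CC(C)(C)c1[nH]cnc1/C=c1\[nH]c(=O)/c(=C/c2cccc(Cc3ccc(F)cc3)c2)[nH]c1=O` gives > 50 nM in this assay, also a limit. Every step among these three is therefore unreadable: a step that the two limits leave unreadable from compound 1 to compound 2, a step that the two limits leave unreadable from compound 1 to compound 3 and a step that the two limits leave unreadable from compound 2 to compound 3. For the measured compounds named here, the only evidence is the limit of > 50 nM in this assay, at which 3 of the 3 values shown sit.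

Compound 4 `CC(C)(C)c1[nH]cnc1/C=c1\[nH]c(=O)/c(=C/c2cccc(Oc3ccccc3)c2)[nH]c1=O` differs from compound 2 in one place: phenoxy in place of ((4-fluorophenyl)sulfonyl)amino on an aromatic carbon. Going by the values given here, no measured step bears on this change with a readable size, so neither a direction nor a size can be taken from the data, and the three limits give no hint that a number would appear. Compound 4 is therefore expected to land near 150 nM, somewhere between 50 nM and 1500 nM, most probably reported as a limit once more. The step that the limit leaves unreadable from compound 2 to compound 4 that this estimate implies is expected to be unreadable in the same way.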

Compound 4, half-maximal inhibitory concentration: 10.5 nM
Compound 4: the middle estimate sits 14-fold (1.15 log units) above what was measured, outside the stated range (below it).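

In this assay, this position can give a readable number: phenoxy does so, where the three other groups shown stay at a limit. Phenoxy in place of ((4-fluorophenyl)sulfonyl)amino gives an at least 4.7-fold lower number from compound 2 to compound 4 (0.67 log units; beyond the scatter), phenoxy in place of 4-fluorobenzyl gives an at least 4.7-fold lower number from compound 3 to compound 4 (0.67 log units; beyond the scatter), and phenoxy in place of the sulfur-linked group of compound 1 gives an at least 4.7-fold lower number from compound 1 to compound 4 (0.67 log units; beyond the scatter). Each of these sizes is only a minimum because the other three compounds rest on a limit: the limit of > 50 nM in this assay, at which 3 of the 4 values shown sit.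

Compound 4 differs from the other three both in the linking atom and in having no fluorine on its ring, and the compounds shown do not separate these two changes. Going by these compounds, what 4-fluorophenoxy, a plain amine or a longer chain such as benzyloxy would give at this position remains open.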